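This account rests on a few compounds, and the source may have more. Where it says the series, first, only, none or still open, it means among the compounds named here.

Compound 2, `CCS(=O)(=O)c1ccc(C)c(C#Cc2cc(Cl)ccc2OCC(=O)O)c1`, was tested in an assay on CHO cells for displacement of a labelled ligand from prostaglandin D2 receptor 2 (Homo sapiens), read by scintillation counting (a higher number here means a weaker inhibitor, a lower number a stronger inhibitor), where compound 2 gives 8.6 nM. Among the compounds with values here, of the two compounds measured so far it gives the lower number. The other, compound 1, `CN(C)C(=O)c1cccc(C#Cc2cc(Cl)ccc2OCC(=O)O)c1`, gives 52 nM in this assay, a higher number that lies beyond the usual scatter of repeated measurements, so compound 2 is the stronger inhibitor of the pair. Compound 3, `Cc1ccc(S(=O)(=O)N(C)CCCN(C)C)cc1C#Cc1cc(Cl)ccc1OCC(=O)O`, has not yet been measured. It differs from compound 2 in one place: (3-(dimethylamino)propyl)(methyl)amino in place of ethyl on a sulfonyl sulfur. Within the data shown here, no pair of measured compounds differing in only one place is available here, so there is nothing measured to say how a change on the sulfonyl sulfur moves the number. The expectation is a modest loss, a step from a 2.3-fold higher number from compound 2 to compound 3 (0.37 log units; beyond the scatter) that could still fall within the scatter. Compound 3 is therefore estimated at 20 nM, with a range from 5 nM to 80 nM.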

Compound 3, inhibition constant: 287 nM
For compound 3 the middle estimate is 14-fold (1.16 log units) below the measured one; measured number outside the range, above it.
By their numbers in this assay, from the lowest: compound 2; then compound 1; then compound 3.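

Replacing ethyl with (3-(dimethylamino)propyl)(methyl)amino on the sulfonyl sulfur gives a 33-fold higher number from compound 2 to compound 3 (1.52 log units; beyond the scatter) in this assay, so compound 3 is a much weaker inhibitor than compound 2. Within the data shown here, this is the first measured change at this place, and it shows that the group on the sulfonyl sulfur can strongly move the number rather than being a free spot for a larger group. No measurement at hand tells which feature of the entering group accounts for the loss.

The change swaps the ethyl for a larger group joined through nitrogen, with a dimethylamino group at the end of its chain, and the compounds shown do not separate these features. A plain dimethylamino group on the sulfonyl sulfur, or a simple propyl chain with no amine, would help to tell them apart.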